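The source may report more compounds than this note shows. Statements on the series, on what has been measured and on what is new or still open speak of the compounds shown alone.

Measured compounds in an ADME assay on MT4 cells (Homo sapiens) for cytotoxicity, read by MTT assay, with a stated time of 5 days; a higher number here means that more compound is tolerated, a lower number that less compound is tolerated:
compound 1, `Cc1cc(C)c(Oc2cc(Nc3ccc(C#N)cc3)ncc2C(=O)NCc2cn(CC(N)=O)nn2)c(C)c1`: 24000 nM
compound 2, `Cc1cc(C)c(Oc2cc(Nc3ccc(C#N)cc3)ncc2C(=O)NCc2cn(Cc3ccccc3C#N)nn2)c(C)c1`: > 219000 nM (a limit of the assay, not a number)
compound 3, `COC(=O)Cn1cc(CNC(=O)c2cnc(Nc3ccc(C#N)cc3)cc2Oc2c(C)cc(C)cc2C)nn1`: 13800 nM

Compound 3 gives the lowest of the two numbers in this assay; its nearest neighbour is compound 1, and the gap between them, a 1.7-fold lower number from compound 1 to compound 3 (0.24 log units; within the scatter), lies within the scatter. Compound 2 reached only a limit of the assay, (the limit of > 219000 nM in this assay, at which 1 of the 3 values shown sits), so the change from compound 1 to compound 2, an at least 9.1-fold higher number from compound 1 to compound 2 (0.96 log units; beyond the scatter), and that from compound 2 to compound 3, an at least 15-fold lower number from compound 2 to compound 3 (1.20 log units; beyond the scatter), are bounds rather than exact sizes.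

Compound 4, `CC(=O)Cn1cc(CNC(=O)c2cnc(Nc3ccc(C#N)cc3)cc2Oc2c(C)cc(C)cc2C)nn1`, differs from compound 3 only at the carbonyl carbon: methyl in place of methoxy on a carbonyl carbon. Among the measured compounds shown here, the one measured step that touches this carbonyl carbon, a 1.7-fold lower number from compound 1 to compound 3 (0.24 log units; within the scatter), stayed within the scatter, whereas the large steps involved the 2-cyanophenyl group at a different place. No step beyond the scatter in this assay is therefore expected here, in either direction. Compound 4 is expected to give about 13000 nM, between 5000 nM and 35000 nM, a step of a 1.1-fold lower number from compound 3 to compound 4 (0.03 log units; within the scatter) that is expected to stay within the scatter.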

Compound 4, half-maximal cytotoxic concentration: 19400 nM
Beside the measured number, compound 4's estimate is 1.5-fold (0.17 log units) below it, within the range that was stated.
By their numbers in this assay, from the lowest: compounds 3, 4 and 1 (each within the scatter of the next). At a limit, above all of these: compound 2.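

In this assay, a third group on this carbonyl carbon behaves like the first two: methyl, like methoxy and amino, leaves the number within the scatter (a 1.4-fold higher number from compound 3 to compound 4 (0.15 log units; within the scatter); a 1.2-fold lower number from compound 1 to compound 4 (0.09 log units; within the scatter)). Acetyl in place of 2-cyanophenyl on the saturated chain carbon gives a large step (an at least 11-fold lower number from compound 2 to compound 4 (1.05 log units; beyond the scatter)), which again is a bound and not an exact size. Compound 2 stands at a limit of the assay, not at a number: the limit of > 219000 nM in this assay, at which 1 of the 4 values shown sits.

On these data alone, whether any group on this carbonyl carbon can move the number beyond the scatter remains open, since the three compared here are only methyl, methoxy and amino. A hydroxyl, which would make a carboxylic acid, or a longer chain in place of the methyl could still behave differently.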